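A few compounds are considered here, and "the series" means these few. Any claim that something is new, unique, unknown or untested is made for them only; others in the source may bear on it.

Measured so far in a functional assay on the whole organism (strain Swiss) with Mus musculus as the target, in the maximal electroshock model, with a stated time of 0.5 h, at a dose of 300 mg/kg by the intraperitoneal route; on this read-out lower numbers stand for a weaker effect and higher numbers for a stronger effect at the one dose given:
- compound 1 `CCC(C(=O)N1CCN(c2ccccc2F)CC1)N1C(=O)CCC1=O` gives 100%
- compound 2 `CCC(C(=O)N1CCN(c2cccc(C)c2)CC1)N1C(=O)CCC1=O` gives 100%

Compound 2 stands level with compound 1 at the digits shown; the only step in this set, no change at the digits printed from compound 1 to compound 2 (within the scatter), is within the scatter, so the two values cannot be ordered.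

Compound 3 `CCC(C(=O)N1CCN(c2cccc(Cl)c2)CC1)N1C(=O)CCC1=O` is the next one in line. It differs from compound 2 in one place: chloro in place of methyl on an aromatic carbon. The variable part of the series is the group on the aromatic ring attached to the amine nitrogen in the ring, and so far that part has been changed once, from 2-fluorophenyl to 3-methylphenyl, with no change in this assay beyond the scatter, as no change at the digits printed from compound 1 to compound 2 (within the scatter) shows. The move from 3-methylphenyl to 3-chlorophenyl is a change of the same kind, of a single heavy atom, at the same place. With both measured values sitting at the same level, no step beyond the scatter is expected for compound 3 in this assay; the estimated step of no change at the digits printed from compound 2 to compound 3 (within the scatter) is a flat one. Compound 3 is expected to give 100%, with a range from 80% to 100%.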

Compound 3, a percentage reported as activity, at one dose (the size of the read-out at that dose, not a potency): 50%
Compound 3: the middle estimate sits 50 percentage points above what was measured; measured number outside the range, below it.
By their numbers in this assay, from the lowest: compound 3; then compounds 1 and 2 (each within the scatter of the next).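

In this assay, the group on the aromatic ring attached to the amine nitrogen in the ring is now shown to matter: chloro in place of methyl on an aromatic carbon, a swap of one heavy atom for one heavy atom, gives a clear step (a number 50 percentage points lower from compound 2 to compound 3 (beyond the scatter)), whereas the earlier change in this part of the series gave none beyond the scatter. The comparison with the 2-fluorophenyl compound points the same way (a number 50 percentage points lower from compound 1 to compound 3 (beyond the scatter)), so among the three compounds shown, 3-chlorophenyl alone stands apart, while 2-fluorophenyl and 3-methylphenyl remain level. No measurement at hand bears on the reason for this difference between chloro and methyl.

Open, going by these compounds, is whether the lower read-out is particular to chloro or would also appear with other groups on the same aromatic carbon, such as bromo, methoxy or an amine. Also open, on these data alone, is whether compound 1 and compound 2 would stay level away from this single dose and time, since a read-out at one dose gives the size of the effect and not a potency.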